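Chloromethyl on the Chain of Compound 2

A few compounds are considered here, and "the series" means these few. Any claim that something is new, unique, unknown or untested is made for them only; others in the source may bear on it.

Measured so far in an in vivo ADME assay on the whole organism for pharmacokinetics, with Rattus norvegicus as the target, at a dose of 3 mg/kg by the oral route; on this read-out lower numbers stand for lower exposure and higher numbers for higher exposure at the dose given:
- compound 1 `COCCOCOc1ccc(-c2nc(-c3ccnc(C)c3)n[nH]2)cc1C#N`: 986 nM
- compound 2 `COCCOCCOc1ccc(-c2nc(-c3ccnc(C)c3)n[nH]2)cc1C#N`: 1880 nM

Within the data shown here, with only two numbers available, compound 2 at 1880 nM lies within the usual scatter of compound 1, so the pair cannot be ranked with confidence.

The next compound, compound 3 `Cc1cc(-c2n[nH]c(-c3ccc(OCCOCCOCCCl)c(C#N)c3)n2)ccn1`, keeps the core of compound 2 and changes only the chain: chloromethyl in place of hydrogen on a saturated chain carbon bound to an oxygen on a saturated carbon. In words, chloromethyl takes the place of hydrogen on a saturated chain carbon bound to an oxygen on a saturated carbon. Cut one bond further out, methoxy becomes 2-chloroethoxy.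

Among the measured compounds shown here, only one measured step bears on this: a 1.9-fold higher number from compound 1 to compound 2 (0.28 log units; within the scatter). That step also alters the chain, but it brings in no chlorine, so it is only an indirect guide. For the measured compounds named here, no measured compound carries chlorine, so the range must stay wide. No shift beyond the scatter is expected in this assay, and the expected change is a 1.3-fold lower number from compound 2 to compound 3 (0.10 log units; within the scatter). For compound 3 the estimated value is 1500 nM, with an expected range of 550 nM to 3800 nM.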

Compound 3, maximal plasma concentration: 1600 nM
Beside the measured number, compound 3's estimate is 1.1-fold (0.03 log units) below it; measured number inside the range.
By their numbers in this assay, from the lowest: compounds 1, 3 and 2 (each within the scatter of the next).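

In this assay, chloromethyl in place of hydrogen on a saturated chain carbon bound to an oxygen on a saturated carbon gives a 1.2-fold lower number from compound 2 to compound 3 (0.07 log units; within the scatter) and the wider comparison gives a 1.6-fold higher number from compound 1 to compound 3 (0.21 log units; within the scatter) so this chlorine-bearing chain cannot be told apart from either earlier chain on this read-out. The earlier pair showed only that a chain without chlorine could be altered with no step beyond the scatter; compound 3 adds that turning methoxy into 2-chloroethoxy, which brings in one carbon and one chlorine, also leaves maximal plasma concentration within the scatter. Nothing measured here speaks to the reason for this result.

From the compounds shown here alone, whether a different group at the end of the chain, such as an amine or a carboxylic acid, would move the number beyond the scatter remains open. So does the effect of a longer chain, and a maximal concentration alone cannot tell how long exposure to any of these compounds lasts.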